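Chloro to methyl exchange across two related cores

This account rests on a few compounds, and the source may have more. Where it says the series, first, only, none or still open, it means among the compounds named here.

In an assay on HEK293 cells for positive allosteric modulation of metabotropic glutamate receptor 5 (Homo sapiens), read by FLIPR (a lower number here means that less compound is needed, a higher number that more compound is needed for the effect), compound 1 `O=C(c1ccc(Cl)cc1)N1CC(c2nc(-c3cccc(F)c3)no2)C1` gives 2500 nM. In this assay compound 2 `Cc1ccc(C(=O)N2CC(c3nc(-c4cccc(F)c4)no3)C2)cc1` gives 6800 nM. The difference between them is methyl in place of chloro on an aromatic carbon, and the step is a 2.7-fold higher number from compound 1 to compound 2 (0.43 log units; beyond the scatter). Compound 3 `O=S(=O)(c1ccc(Cl)cc1)N1CC(c2nc(-c3cccc(Cl)c3)no2)C1` is recorded in this assay only as a limit, > 10000 nM, which is the limit of > 10000 nM in this assay, at which 1 of the 3 values shown sits. How the core of compound 3 differs from the core of compound 1 is not broken down here. Compound 4 `Cc1cccc(-c2noc(C3CN(S(=O)(=O)c4ccc(Cl)cc4)C3)n2)c1` carries methyl in place of chloro on an aromatic carbon; since the place is meta to a large group here and para to a large group in the earlier pair, this is the same kind of change rather than the same one. Compound 4 is therefore expected to stay at or beyond the limit, an estimated 25000 nM with a step that the limit leaves unreadable from compound 3 to compound 4, resting on a 2.7-fold higher number from compound 1 to compound 2 (0.43 log units; beyond the scatter) and the limit of compound 3.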

Compound 4, half-maximal effective concentration: > 10000 nM
Compound 4: only a limit was reported; the forecaster's own chance of this, stated with the estimate: 85%; the middle value does not contradict the limit.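

Compound 3 and compound 4 both stand only as limits in this assay, so no step between them can be read: the limit of > 10000 nM in this assay, at which 2 of the 4 values shown sit.

Left open is whether 3-chlorophenyl to 3-methylphenyl changes the number at all on the core of compound 3.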